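Thienyl for tolyl in a spirocyclic oxindole series

The source may report more compounds than this note shows. Statements on the series, on what has been measured and on what is new or still open speak of the compounds shown alone.

Measured so far:
- compound 1 `CN1C[C@@H](c2cccs2)[C@@]2(Cc3ccccc3C2=O)[C@@]12C(=O)Nc1ccccc12`: 20%
- compound 2 `Cc1ccc([C@@H]2CN(C)[C@]3(C(=O)N(C)c4ccccc43)[C@]23Cc2ccccc2C3=O)cc1`: 13.9%

In a functional assay on the whole organism (strain Wister albino) for inhibition, with Rattus norvegicus as the target, read by paw edema, with stated times of 1 h and 4 h, at a dose of 50 mg/kg by the intraperitoneal route (a lower number here means less inhibition, a higher number more inhibition at the dose given (going by the name of the read-out)), compound 1 gives 20%. In this assay compound 2 gives 13.9%. The two numbers lie within the scatter of each other, so compound 2 stands level with compound 1 on the numbers shown; no ranking can be drawn from them.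

Compound 3 `CN1C(=O)[C@@]2(c3ccccc31)N(C)C[C@@H](c1cccs1)[C@@]21Cc2ccccc2C1=O` has not been measured. It differs from compound 2 as follows: thiophen-2-yl in place of 4-methylphenyl on a saturated ring carbon. Compound 1 already carries the entering group together with a different amide substitution and returns a number within the scatter of compound 2, so no step beyond the scatter is expected here.

Compound 3 is therefore expected to give about 17% in this assay, with a range from 7% to 28%. The expected step is a number 3.1 percentage points higher from compound 2 to compound 3 (within the scatter), within the usual scatter.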

Compound 3, a percentage reported as inhibition, in the whole organism at one dose (the size of the read-out at that dose, not a potency): 12.9%
Compound 3: middle estimate off by 4.1 percentage points, on the high side; low and high end bracket the measured number.
By their numbers in this assay, from the lowest: compounds 3, 2 and 1 (each within the scatter of the next).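

In this assay thiophen-2-yl in place of 4-methylphenyl on the saturated ring carbon gives a number 1 percentage points lower from compound 2 to compound 3 (within the scatter) and so, with methyl on the amide-type ring nitrogen in both compounds, this position does not separate the two aromatic rings at the dose given. With thiophen-2-yl held constant, methyl in place of hydrogen on the amide-type nitrogen can now be read as a single change: it gives a number 7.1 percentage points lower from compound 1 to compound 3 (within the scatter) and does not separate that pair either. No measurement shown offers an explanation for either result.

From the compounds shown here alone, it remains open whether a group of another kind on this saturated ring carbon, such as an amine or a carboxylic acid, would give a step beyond the scatter in this assay. Going by these compounds, it is equally open whether a longer chain in place of methyl on the amide-type nitrogen would do so.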